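The compounds below may be only part of what the source reports. "The series", "measured", "known", "first", "only" and "open" are said of these compounds alone.

Compound 1 `Cn1nc(-c2ccccc2)c2c1OC(N)=C(C#N)C2c1ccc(F)cc1` gives > 10000 nM, which is a limit of the assay and not a number.
Compound 2 `COc1ccc(-c2nn(C)c3c2C(c2ccc(F)cc2)C(C#N)=C(N)O3)cc1OC` gives > 10000 nM, again a limit rather than a number.
Compound 3 `COc1ccc(C2C(C#N)=C(N)Oc3c2c(-c2ccccc2)nn3C)cc1F` gives > 10000 nM, also a limit.

All three were tested in a functional assay on NCI-H2122 cells (Homo sapiens) for inhibition, read by microscopy, with a stated time of 10 days; a lower number here means a stronger inhibitor, a higher number a weaker inhibitor. Within this assay compound 1 therefore has no measured value, only a limit, and the same holds for the two other compounds shown, as summarised by the limit of > 10000 nM in this assay, at which 3 of the 3 values shown sit.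

Compound 4 `Cn1nc(-c2ccccc2)c2c1OC(N)=C(C#N)C2c1ccc(OC(F)(F)F)cc1` differs from compound 1 by trifluoromethoxy in place of fluoro on an aromatic carbon. The two steps already taken from compound 1 touch other parts of the molecule and are a step that the two limits leave unreadable from compound 1 to compound 2 and a step that the two limits leave unreadable from compound 1 to compound 3, so neither gives a readable size or direction. Nothing measured here separates any two of these compounds, and no change around the shared core has yet produced a number inside the range of this assay.

The expectation for compound 4 rests on that picture alone: compound 4 is estimated at 15000 nM, with a range from 4000 nM to 60000 nM, and most likely it will again be reported only as a limit. That estimate corresponds to an expected step that the limit leaves unreadable from compound 1 to compound 4, which is a guess rather than a measured effect.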

Compound 4, half-maximal inhibitory concentration: 5500 nM
Beside the measured number, compound 4's estimate is 2.7-fold (0.44 log units) above it; the range from low to high includes it.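

Trifluoromethoxy in place of fluoro, on an aromatic carbon of a six-membered aromatic ring of carbon only, gives an at least 1.8-fold lower number from compound 1 to compound 4 (0.25 log units; that floor lies within the scatter), the only step among these compounds that can be read at all. Compound 1 has only a limit, so this figure is a floor and not a size: the true gap could be wider, but the floor on its own does not rise out of the scatter of repeated measurements. Even so, this is the one place on the shared core where a change among the compounds shown gives a value inside the range of this assay: the limit of > 10000 nM in this assay, at which 3 of the 4 values shown sit.

The compounds shown leave open whether the effect belongs to trifluoromethoxy in particular or whether other groups at this place, such as a longer chain like butoxy, an amine or a carboxylic acid, would also give a number inside the range. They also leave open whether trifluoromethoxy at this place would bring a measurable value when combined with the 3,4-dimethoxyphenyl group of compound 2.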